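Aryl variation on the carbonyl carbon: towards compound 4

The compounds below may be only part of what the source reports. "The series", "measured", "known", "first", "only" and "open" are said of these compounds alone.

Measured so far:
compound 1 `COc1cc(-c2cc(/C=C/C(=O)c3ccc(N)cc3)[nH]n2)cc(OC)c1OC` — 93%
compound 2 `COc1cc(-c2cc(/C=C/C(=O)c3ccc(Cl)c(Cl)c3)[nH]n2)cc(OC)c1OC` — 95%
compound 3 `COc1ccc(C(=O)/C=C/c2cc(-c3cc(OC)c(OC)c(OC)c3)n[nH]2)cc1OC` — 90%

All three share a core and differ only in the aryl group on the carbonyl carbon. In a functional assay on BT-549 cells (Homo sapiens) for cytotoxicity, read by sulforhodamine B assay, with a stated time of 48 h, tested at 0.1 uM (a higher number here means a weaker effect of the compound at the concentration tested, a lower number a stronger effect), compound 1 gives 93%, which is the second highest of the three numbers. Its nearest neighbour is compound 2, with a number 2 percentage points higher from compound 1 to compound 2 (within the scatter); the furthest is compound 3, with a number 3 percentage points lower from compound 1 to compound 3 (within the scatter). Between the two halogen- and methoxy-bearing aryls the step is a number 5 percentage points lower from compound 2 to compound 3 (within the scatter). Every step measured so far in this assay lies within the scatter, so the three aryl groups are not separated by the data.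

The next compound is compound 4 `COc1cc(-c2cc(/C=C/C(=O)c3ccc(F)c(F)c3)[nH]n2)cc(OC)c1OC`. It differs from compound 1 as follows:
3,4-difluorophenyl in place of 4-aminophenyl on a carbonyl carbon

For the measured compounds named here, the steps that bear on this change are the one from compound 1 to compound 2 (another dihalogenated aryl in place of the 4-aminophenyl) and, less directly, the steps to compound 3. None of them moved the read-out beyond the scatter. Accordingly no step beyond the scatter is expected in this assay, and the estimated change is no change at the digits printed from compound 1 to compound 4 (within the scatter). Compound 4 is therefore expected to give 93%, with a range from 84% to 100%.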

Compound 4, a percentage reported as activity, at one concentration (the size of the read-out at that concentration, not a potency): 105%
Compound 4: the middle estimate sits 12 percentage points below what was measured, outside the stated range (above it).
By their numbers in this assay, from the lowest: compounds 3, 1, 2 and 4 (each within the scatter of the next, the first and the last beyond it).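

In this assay, the aryl group on the carbonyl carbon now gives its first steps beyond the scatter: 3,4-difluorophenyl in place of 4-aminophenyl gives a number 12 percentage points higher from compound 1 to compound 4 (beyond the scatter), and in place of 3,4-dimethoxyphenyl it gives a number 15 percentage points higher from compound 3 to compound 4 (beyond the scatter), so this position is not silent in this assay, although both steps are modest. The exchange of one dihalogenated aryl for the other gives a number 10 percentage points higher from compound 2 to compound 4 (within the scatter), which leaves 3,4-difluorophenyl and 3,4-dichlorophenyl unseparated, while compound 2 itself stays within the scatter of compound 1 and compound 3, so halogen-bearing aryls as a class do not separate from the other two. Nothing measured here accounts for these steps.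

Still open, on these data alone, is whether the separation belongs to the fluorine atoms or to the pair of them: a 4-fluorophenyl or a 3-fluorophenyl on the carbonyl carbon would test that, and a 4-trifluoromethylphenyl would extend the comparison beyond single halogen atoms. As far as these compounds go, all four compounds were read at a single concentration, so these numbers give no potency, and whether the order of compound 3 and compound 4 holds at higher concentrations remains unknown.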